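A dimethoxyphenyl arm in place of a phenylethenyl arm

This account rests on a few compounds, and the source may have more. Where it says the series, first, only, none or still open, it means among the compounds named here.

Compound 1 `Cc1cc(O)c(C2=NN(c3ccc(S(N)(=O)=O)cc3)C(c3ccccc3O)C2)cc1Cl` gives 39700 nM in a functional assay on EKVX cells (Homo sapiens) for antiproliferative activity, with a stated time of 48 h; on this read-out higher numbers stand for lower toxicity in this test and lower numbers for higher toxicity in this test.
Compound 2 `Cc1cc(O)c(C2=NN(c3ccc(S(N)(=O)=O)cc3)C(/C=C/c3ccccc3)C2)cc1Cl` gives 87400 nM in this assay.

Among the two measured compounds, compound 2 stands with the highest number, meaning the lower toxicity of the pair; its nearest neighbour is compound 1, and the step between them is a 2.2-fold higher number from compound 1 to compound 2 (0.34 log units; beyond the scatter).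

Compound 3 `COc1ccc(C2CC(c3cc(Cl)c(C)cc3O)=NN2c2ccc(S(N)(=O)=O)cc2)cc1OC` has not yet been measured. It differs from compound 2 in one place: 3,4-dimethoxyphenyl in place of 2-phenylethenyl on a saturated ring carbon. Among the compounds with values here, the only measured step that bears on this change is the one from compound 1 to compound 2, where an aromatic ring sitting directly on the saturated ring carbon was exchanged for the phenylethenyl arm and the number rose modestly. Compound 3 returns an aromatic ring directly to that carbon, though one carrying two methoxy groups rather than a hydroxyl. On that basis a modest move back toward the number of compound 1 is expected for compound 3, estimated as a 1.7-fold lower number from compound 2 to compound 3 (0.24 log units; within the scatter). The value expected for compound 3 in this assay is 50000 nM, with a range from 20000 nM to 130000 nM.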

Compound 3, concentration lethal to 50% of the cells: > 100000 nM
Compound 3 ended at the assay's limit (the forecaster's own chance of this, stated with the estimate: 5%); middle value at least 2.0-fold (0.30 log units) away from the limit.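

In this assay compound 3 gives > 100000 nM, which is a limit of the assay and not a number: the limit of > 100000 nM in this assay, at which 1 of the 3 values shown sits.

Exchanging 2-hydroxyphenyl for 3,4-dimethoxyphenyl on the saturated ring carbon gives an at least 2.5-fold higher number from compound 1 to compound 3 (0.40 log units; beyond the scatter), so an aromatic ring attached directly at this position does not by itself keep the number close to that of compound 1; the substituents on that ring matter in this test. Exchanging 2-phenylethenyl for 3,4-dimethoxyphenyl gives an at least 1.1-fold higher number from compound 2 to compound 3 (0.05 log units; that floor lies within the scatter), and because that floor lies within the scatter, the result sets no order between these two arms, showing only that both belong to the high end of the numbers seen here.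

The compounds shown leave open which of the two methoxy groups accounts for the step away from compound 1, and where a phenyl ring with a single methoxy group, or with an amine in place of the methoxy groups, would fall. They also leave open how far beyond the limit compound 3 lies, and so whether it truly separates from compound 2.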